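This account rests on a few compounds, and the source may have more. Where it says the series, first, only, none or still open, it means among the compounds named here.

Measured in an ADME assay on a cell-free system (plasma, Homo sapiens) for protein binding:
compound 1 `COCCOc1cc2oc(=O)n(CCC(=O)O)c2cc1Cl`: 70.7%
compound 2 `O=C(O)CCn1c(=O)oc2cc(Cl)c(Cl)cc21`: 98.2%
compound 3 `C[C@@H](Oc1cc2oc(=O)n(CCC(=O)O)c2cc1Cl)c1cccnn1`: 68.1%

Compound 1 sits level with compound 3 within the scatter, and only compound 2 stands clearly apart. Compound 4 `O=C(O)CCn1c(=O)oc2cc(OCC3CC3)c(Cl)cc21` differs from compound 1 in one place, with 2-methoxyethoxy giving way to cyclopropylmethoxy: cyclopropyl in place of methoxymethyl on a saturated chain carbon bound to an oxygen on an aromatic ring. For the measured compounds named here, two measured steps touch this group. Chloro in its place gave a 16-fold lower unbound fraction from compound 1 to compound 2 (1.21 log units; beyond the scatter), while the larger group on the oxygen gave a 1.1-fold higher unbound fraction from compound 1 to compound 3 (0.04 log units; within the scatter). Neither is the same change, so they only bracket it. A moderate move towards compound 2 is expected, well short of that large step. The expected change is a 2.4-fold lower unbound fraction from compound 1 to compound 4 (0.39 log units; beyond the scatter). For compound 4 the estimated value is 88%, with an expected range of 78% to 95%.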

Compound 4, plasma protein binding: 96%
Compound 4: middle estimate off by 3.0-fold (0.48 log units) (unbound fraction), on the high side, outside the stated range (above it).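

In this assay, the oxygen-bound side chain proves far from neutral: cyclopropyl in place of methoxymethyl, with the heavy-atom count unchanged, gives a 7.3-fold lower unbound fraction from compound 1 to compound 4 (0.86 log units; beyond the scatter). The step from the larger group is of similar size, at an 8.0-fold lower unbound fraction from compound 3 to compound 4 (0.90 log units; beyond the scatter), so compound 1 and compound 3 lie on one side and compound 4 moves towards the chloro compound. Even so, cyclopropylmethoxy in place of chloro still gives a 2.2-fold higher unbound fraction from compound 2 to compound 4 (0.35 log units; beyond the scatter), leaving the two apart.

Nothing given here explains this shift. On these data alone, whether the ring or the missing oxygen of methoxymethyl drives it remains open, and a plain propyl chain or a cyclobutyl ring in that place would separate the two.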